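Chain length at the aryl urea: from compound 2 to compound 3

This account rests on a few compounds, and the source may have more. Where it says the series, first, only, none or still open, it means among the compounds named here.

In an assay on isolated protein for inhibition of acyl-CoA:cholesterol acyltransferase (Oryctolagus cuniculus) (a lower number here means a stronger inhibitor, a higher number a weaker inhibitor), compound 1 `CCCCCCCCc1ccc(NC(=O)Nc2c(C(C)C)cccc2C(C)C)cc1` gives 11 nM. For the measured compounds named here, compound 2 `Cc1ccc(NC(=O)Nc2c(C(C)C)cccc2C(C)C)cc1` gives 250 nM in this assay , the highest of the two numbers so far; its nearest neighbour is compound 1, and the step of a 23-fold higher number from compound 1 to compound 2 (1.36 log units; beyond the scatter) separates them. Compound 3 `CCCCCCCCCc1ccc(NC(=O)Nc2c(C(C)C)cccc2C(C)C)cc1` is not yet measured. It differs from compound 2 by octyl in place of hydrogen on a saturated chain carbon bound to an aromatic carbon; the same difference, cut one bond further out, reads methyl to nonyl. Going by the values given here, the only measured step that bears on this change is a 23-fold higher number from compound 1 to compound 2 (1.36 log units; beyond the scatter), which removed a chain of this kind and was large. Restoring a chain of the next length is therefore expected to reverse that step, giving an estimated step of a 25-fold lower number from compound 2 to compound 3 (1.40 log units; beyond the scatter) in this assay. For compound 3 the expected value is 10 nM, with a range from 3 nM to 35 nM.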

Compound 3, half-maximal inhibitory concentration: 9 nM
Compound 3: middle estimate off by 1.1-fold (0.05 log units), on the high side, within the range that was stated.
By their numbers in this assay, from the lowest: compounds 3 and 1 (each within the scatter of the next); then compound 2.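

In this assay the step of a 28-fold lower number from compound 2 to compound 3 (1.44 log units; beyond the scatter) shows that the large difference at this position is not confined to a single chain: octyl in place of hydrogen on a saturated chain carbon bound to an aromatic carbon gives a change of similar size to the one seen earlier with heptyl. The further step a 1.2-fold lower number from compound 1 to compound 3 (0.09 log units; within the scatter) lies within the scatter, so compound 1 and compound 3 cannot be ordered, and the added methyl at the chain end has no readable effect. Nothing measured here accounts for the effect of chain length at this position.

The compounds shown leave open how the number changes at chain lengths between those of compound 2 and compound 1, and whether a longer chain holds the same level. Also open, on these data alone, is whether a chain ending in a carboxylic acid or an amine would keep it.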